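A few compounds are considered here, and "the series" means these few. Any claim that something is new, unique, unknown or untested is made for them only; others in the source may bear on it.

Compound 2 `Cc1cc(C)n2nc(SCc3cc(=O)c4cc(Cl)ccc4o3)nc2n1` stands at the edge of what the measurement can report. In a functional assay on HEp-2 cells (Homo sapiens) for cytotoxicity, read by MTT assay, with a stated time of 72 h (a lower number here means a stronger inhibitor, a higher number a weaker inhibitor), compound 2 gives > 25000 nM, which is a limit of the assay and not a number. Compound 1 `Cc1ccc2oc(CSc3nc4nc(C)cc(C)n4n3)cc(=O)c2c1` carries chloro in place of methyl on an aromatic carbon. In this assay compound 1 gives > 25000 nM, likewise a limit. Between the two lies a step that the two limits leave unreadable from compound 1 to compound 2 because of the limit of > 25000 nM in this assay, at which 2 of the 2 values shown sit. Compound 3 `Cc1cc(C)n2nc(SCc3cc(=O)c4ccccc4o3)nc2n1` differs from compound 2 by hydrogen in place of chloro on an aromatic carbon. Among the measured compounds shown here, no measured step tells what removing this group does. Compound 3 is therefore expected to give about 40000 nM in this assay, within 15000 nM to 120000 nM, an estimated step that the limit leaves unreadable from compound 2 to compound 3 that most likely again ends as a limit.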

Compound 3, half-maximal inhibitory concentration: > 25000 nM
Compound 3: only a limit was reported (the forecaster's own chance of this, stated with the estimate: 85%); the middle value does not contradict the limit.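

No step can be read among compound 1, compound 2 and compound 3, since each value is only a limit: the limit of > 25000 nM in this assay, at which 3 of the 3 values shown sit.

From the compounds shown here alone, whether methyl, chloro or hydrogen on that aromatic carbon makes any difference in this assay stays open.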